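The source may report more compounds than this note shows. Statements on the series, on what has been measured and on what is new or still open speak of the compounds shown alone.

Of the compounds shown here, three carrying the same butylene-dioxy-linked core have been measured in an assay on HEK293 cells for positive allosteric modulation of metabotropic glutamate receptor 3 (Rattus norvegicus), read by thallium flux, with a stated time of 2.5 min; a lower number here means a smaller maximal response, a higher number a larger maximal response. Compound 1 `CCC(=O)c1ccc(OCCCCOc2cc(C(=O)O)ccc2OC)c(C)c1O` gives 62.5%. Compound 2 `Cc1ccc(C(=O)O)cc1OCCCCOc1ccc(C(=O)CC(C)C)c(O)c1C` gives 29.4%, and compound 3 `Cc1c(OCCCCOc2ccc(C(=O)O)c(Cl)c2)ccc(C(=O)CC(C)C)c1O` gives 49.5%. Compound 2 thus stands lowest of the three: the step of a number 20.1 percentage points higher from compound 2 to compound 3 (beyond the scatter) lies beyond the scatter, and the gap to compound 1 is wider still.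

Compound 4 `COc1ccc(C(=O)O)cc1OCCCCOc1ccc(C(=O)CC(C)C)c(O)c1C` differs from compound 2 in one place, (methoxy in place of methyl on an aromatic carbon). Among the compounds with values here, no measured step covers exactly this change. Within the data shown here, the one step that starts from compound 2, a number 20.1 percentage points higher from compound 2 to compound 3 (beyond the scatter), exchanges the whole carboxy-bearing aryl group and points upward. Compound 1, which also carries a methoxy group on its carboxy-bearing ring, gives 62.5%, the highest value seen, but it differs from compound 2 in more than one place, so its value can only hint at the direction.

Taken together, the author expects a moderate rise in this assay for compound 4, of about a number 15.6 percentage points higher from compound 2 to compound 4 (beyond the scatter), with considerable uncertainty. The estimate for compound 4 in this assay is therefore 45%, in a range from 25% to 65%.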

Compound 4, largest response reached (reported as percent of maximum), in percent of the reference or control that the assay uses: 100%
Compound 4: the middle estimate sits 55 percentage points below what was measured; the whole stated range lies below it.
By their numbers in this assay, from the lowest: compound 2; then compound 3; then compound 1; then compound 4.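

In this assay, within the data shown here, the exchange of methyl for methoxy, on an aromatic carbon ortho to a large group and para to a carboxy group, gives a single-place reading on this ring for the first time: a number 70.6 percentage points higher from compound 2 to compound 4 (beyond the scatter). The earlier compounds shown here could only hint at this, as compound 1 and compound 2 differ in more than one place, whereas the methoxy group now separates compound 2 and compound 4 on its own. With the methoxy group held in place, the other end of the molecule also proves to count, with a number 37.5 percentage points higher from compound 1 to compound 4 (beyond the scatter) for isopropyl in place of methyl on a saturated chain carbon bound to a carbonyl carbon, and no measurement at hand offers an explanation for the size of either step.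

The compounds shown leave open whether the rise is particular to methoxy or would also appear with an ethoxy group, a hydroxy group or a fluorine atom at the same place. They also leave open how far a longer chain on the carbonyl carbon would carry this response, and whether an amide in place of the carboxylic acid would keep it.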